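This account rests on a few compounds, and the source may have more. Where it says the series, first, only, none or still open, it means among the compounds named here.

Measured compounds in an assay on CHO cells for displacement of a labelled ligand from adenosine receptor A1 (Homo sapiens), with a stated time of 60 min, tested at 10 uM; on this read-out higher numbers stand for more inhibition at the one concentration tested (going by the name of the read-out) and lower numbers for less inhibition:
compound 1 `CCOC(=O)C1=C(c2ccccc2)NC(=O)NC1c1ccco1`: 3%
compound 2 `CC1=C(C(=O)OC(C)C)C(c2ccco2)NC(=O)N1C`: 28%
compound 3 `CC1=C(C(=O)OC(C)C)C(c2ccoc2)NC(=O)N1`: 25%

Compound 3 stands second highest of the three numbers in this assay . Its nearest neighbour is compound 2, whose value lies within the scatter of that of compound 3; the furthest is compound 1, whose value lies beyond the scatter below compound 3. Compound 4 `CC1=C(C(=O)OC(C)C)C(c2ccoc2)NC(=O)N1C` differs from compound 3 in one place: methyl in place of hydrogen on an amide-type nitrogen in a ring. Among the compounds with values here, no step between measured compounds that share this one change is available, so the expectation rests on what the three values show. Compound 2 also carries a methyl on an amide-type nitrogen in a ring and sits within the scatter of compound 3. In this assay the step is expected to be none beyond the scatter. For compound 4 the estimate is 27%, range 12% to 42%, an expected step of a number 2 percentage points higher from compound 3 to compound 4 (within the scatter).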

Compound 4, a percentage reported as inhibition, at one concentration (the size of the read-out at that concentration, not a potency): 23%
Beside the measured number, compound 4's estimate is 4 percentage points above it, and the stated range covers the measured number.
By their numbers in this assay, from the lowest: compound 1; then compounds 4, 3 and 2 (each within the scatter of the next).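

In this assay, within the data shown here, methyl in place of hydrogen on an amide-type nitrogen in a ring gives a number 2 percentage points lower from compound 3 to compound 4 (within the scatter) and so provides the first direct reading of this change at this position, on a compound bearing furan-3-yl. With that methyl present, furan-3-yl in place of furan-2-yl on a saturated ring carbon gives a number 5 percentage points lower from compound 2 to compound 4 (within the scatter) in the same assay, so neither single change moves the number beyond the scatter. Nothing available offers an explanation for either step. On these data alone, how a longer chain such as propyl in place of that methyl would read in this assay stays open. As far as these compounds go, whether either change matters for potency also stays open, since these readings come from one concentration.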